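A Methylseleno Group Replacing a Long Selenocyanate Chain

The source may hold more compounds than are shown below. What is called first, only, known or untested is meant among the compounds shown, and "the series" means these compounds.

Three compounds sharing one core have been examined in a functional assay on RKO cells (Homo sapiens) for inhibition, read by MTT assay, with a stated time of 48 h; on this read-out lower numbers stand for stronger inhibition and higher numbers for weaker inhibition. Compound 1, `C[Se]c1ccc(N(C)c2nc(C)nc3ccccc23)cc1C`, gives 8 nM, and compound 2, `Cc1nc(N(C)c2ccc([Se]C#N)c(F)c2)c2ccccc2n1`, gives 8 nM. Compound 3, `COc1ccc(N(C)c2nc(C)nc3ccccc23)cc1OCCCCCC[Se]C#N`, gives 1540 nM, the highest number of the three; the gap from compound 1 and from compound 2 to compound 3 lies well beyond the scatter in each case, so compound 3 is the weakest inhibitor among those measured.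

Compound 4, `COc1ccc(N(C)c2nc(C)nc3ccccc23)cc1[Se]C`, has not yet been measured. It differs from compound 3 in one place: a group of 2 heavy atoms (1 carbon, 1 selenium; no ring) in place of a group of 10 heavy atoms (7 carbon, 1 nitrogen, 1 oxygen, 1 selenium; no ring), on an aromatic carbon

Among the measured compounds shown here, no pair of measured compounds differs in only one place, so the size of this step cannot be read directly from the data. What the data show is that compound 1 and compound 2, which each carry a small selenium-bearing group directly on the aromatic ring, sit far below compound 3 in this assay. On that basis compound 4 is expected to move strongly toward lower numbers, with the step estimated as a 51-fold lower number from compound 3 to compound 4 (1.71 log units; beyond the scatter). Compound 4 is accordingly estimated at 30 nM, within a range of 5 nM to 200 nM.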

Compound 4, half-maximal inhibitory concentration: 11 nM
Estimate against measurement, compound 4: 2.7-fold (0.44 log units) above; the measured number falls inside the stated range.
By their numbers in this assay, from the lowest: compounds 1, 2 and 4 (each within the scatter of the next); then compound 3.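

In this assay, among the compounds shown here, the earlier compounds offered no pair differing in one place, so this is the first direct reading of a change at this aromatic carbon, ortho to a methoxy group: with everything else held constant, the change gives a 140-fold lower number from compound 3 to compound 4 (2.15 log units; beyond the scatter). The result therefore ties a large difference to this one position and shows that a group of just 2 heavy atoms, one carbon and one selenium, is enough there for compound 4 to reach 11 nM, so the long chain with its nitrile end is not needed for a low number on this read-out. No measurement offered here accounts for the size of this step.

From the compounds shown here alone, the step removes the oxygen link, the chain and the selenocyanate end together, so it remains open which of these parts sets the difference, and a shorter chain ending in selenocyanate would bear on that question. Going by these compounds, it also remains open whether selenium itself matters on this carbon, and how a methylthio group, a plain methyl group or a bare hydrogen there would compare with the methylseleno group.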